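Ethyl in place of trifluoromethyl on the aryl substituent

The compounds below may be only part of what the source reports. "The series", "measured", "known", "first", "only" and "open" are said of these compounds alone.

For the measured compounds named here, compound 2 `Cc1cc(-n2ccc(N3CCNC3=O)n2)c2c(n1)N(c1ccc(C#N)cc1C(F)(F)F)CC2` gives 32.4 nM in an assay on CHO cells for displacement of a labelled ligand from corticotropin-releasing factor receptor 1 (Homo sapiens) (a lower number here means a stronger inhibitor, a higher number a weaker inhibitor), the lowest of the two numbers so far. Compound 1 `Cc1cc(-n2ccc(N3CCNC3=O)n2)c2c(n1)N(c1ccc(C#N)cc1C)CC2` gives 67.6 nM in this assay. Compound 3 `CCc1cc(C#N)ccc1N1CCc2c(-n3ccc(N4CCNC4=O)n3)cc(C)nc21` is not yet measured; it differs from compound 2 by ethyl in place of trifluoromethyl on an aromatic carbon. Going by the values given here, the only measured step at this position, a 2.1-fold lower number from compound 1 to compound 2 (0.32 log units; beyond the scatter), was modest. Ethyl is neither of the two groups measured there, so compound 3 is expected to land between compound 1 and compound 2, and the step of a 1.4-fold higher number from compound 2 to compound 3 (0.14 log units; within the scatter) is expected to be small. Compound 3 is therefore estimated at 45 nM, range 20 nM to 110 nM.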

Compound 3, half-maximal inhibitory concentration: 50.1 nM
The estimate for compound 3 lay 1.1-fold (0.05 log units) below the measured number; the measured number falls inside the stated range.
By their numbers in this assay, from the lowest: compounds 2, 3 and 1 (each within the scatter of the next, the first and the last beyond it).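

In this assay, ethyl in place of trifluoromethyl gives a 1.5-fold higher number from compound 2 to compound 3 (0.19 log units; within the scatter) and methyl extended to ethyl gives a 1.3-fold lower number from compound 1 to compound 3 (0.13 log units; within the scatter) as its step at this position. For the compounds shown here, both steps lie within the scatter, so ethyl is not separated from either group, even though trifluoromethyl and methyl are separated from each other by a 2.1-fold lower number from compound 1 to compound 2 (0.32 log units; beyond the scatter) as the only step beyond it. No measurement available here bears on why these groups read so closely.

On these data alone, whether a longer chain, a methoxy group or a chlorine atom on this aromatic carbon would fall outside this narrow band remains open. So does the effect of a bare hydrogen here.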